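Ethyl for fluoro at the ring carbon of compound 2

The compounds below may be only part of what the source reports. "The series", "measured", "known", "first", "only" and "open" are said of these compounds alone.

The compounds share one core. Compound 1 `Cc1ccc2[nH]cc(-c3nn[nH]n3)c(=O)c2c1` carries a methyl on the six-membered aromatic ring of carbon only, and in a functional assay on the whole organism (strain Sprague-Dawley) for inhibition, with Rattus norvegicus as the target (on this read-out lower numbers stand for an effect already at smaller amounts and higher numbers for an effect only at larger amounts of compound), compound 1 gives 1.25 mg/kg. Compound 2 `O=c1c(-c2nn[nH]n2)c[nH]c2ccc(F)cc12` carries fluoro in place of that methyl; in this assay compound 2 gives 1.25 mg/kg. The single step measured so far, no change at the digits printed from compound 1 to compound 2 (within the scatter), lies within the scatter, so compound 2 stands level with compound 1 at the digits shown, with no other compound to place it against.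

Compound 3 `CCc1ccc2[nH]cc(-c3nn[nH]n3)c(=O)c2c1` is the next member. Its change from compound 2: ethyl in place of fluoro on an aromatic carbon. For the measured compounds named here, only the step from compound 1 to compound 2 bears on this change: two unlike groups at the same aromatic carbon gave the same reading in this assay, and nothing measured here points either way for an ethyl at that place. For compound 3 the expected step is therefore no change at the digits printed from compound 2 to compound 3 (within the scatter), none beyond the scatter. Compound 3 is accordingly estimated at 1.25 mg/kg in this assay, with a range from 0.5 mg/kg to 3 mg/kg.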

Compound 3, minimum effective dose: < 5 mg/kg
Compound 3 ended at the assay's limit; the forecaster's own chance of this, stated with the estimate: 5%; the middle value does not contradict the limit.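

In this assay compound 3 gives < 5 mg/kg as a limit of the assay and not a number. For the compounds shown here, no step from compound 1 or from compound 2 to compound 3 can be read: the limit of < 5 mg/kg in this assay, at which 1 of the 3 values shown sits. The compounds shown leave open whether ethyl on that aromatic carbon shifts the minimum effective dose at all, relative to methyl or fluoro.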